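Acylguanidine series: pentyl for 1-phenylethyl on the urea nitrogen

A few compounds are considered here, and "the series" means these few. Any claim that something is new, unique, unknown or untested is made for them only; others in the source may bear on it.

Measured compounds:
- compound 1 `Cc1nc(N)sc1CCCN/C(N)=N/C(=O)N[C@H](C)c1ccccc1`: 45.7 nM
- compound 2 `N/C(=N\C(=O)NCc1ccccc1)NC1CCc2nc(N)sc2C1`: 4370 nM
- compound 3 `Cc1nc(N)sc1CCCN/C(N)=N/C(=O)Nc1ccccc1`: 3390 nM

In a functional assay on HEK293T cells for agonist activity at histamine H2 receptor (Homo sapiens), read by beta-arrestin recruitment (on this read-out higher numbers stand for an effect only at larger amounts of compound and lower numbers for an effect already at smaller amounts), compound 1 gives the lowest number of the three. Among the compounds with values here, compound 3 stands nearest, with a 74-fold higher number from compound 1 to compound 3 (1.87 log units; beyond the scatter) separating them; compound 2 lies further away again, and its value and that of compound 1 are far apart, though the two differ in more than one place and no single step is drawn between them.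

Compound 4 `CCCCCNC(=O)/N=C(\N)NCCCc1sc(N)nc1C` is not yet measured. It differs from compound 1 in one place: pentyl in place of 1-phenylethyl on an amide-type nitrogen. Within the data shown here, the only step that bears on this position is the one from compound 1 to compound 3, where a 74-fold higher number from compound 1 to compound 3 (1.87 log units; beyond the scatter) was found when the six-membered ring was kept and the branch removed. Compound 4 removes the ring but keeps a chain of comparable length, so a loss is expected, smaller than that step. For compound 4 the estimate in this assay is 400 nM (range 80 nM to 2500 nM), meaning an expected step of an 8.8-fold higher number from compound 1 to compound 4 (0.94 log units; beyond the scatter).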

Compound 4, half-maximal effective concentration: 178 nM
The estimate for compound 4 lay 2.2-fold (0.35 log units) above the measured number; the measured number falls inside the stated range.
By their numbers in this assay, from the lowest: compound 1; then compound 4; then compounds 3 and 2 (each within the scatter of the next).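

In this assay the ring of 1-phenylethyl is not needed on this amide-type nitrogen for a low number: pentyl, with no ring, costs only a 3.9-fold higher number from compound 1 to compound 4 (0.59 log units; beyond the scatter) as a modest step. Having an aromatic ring on this nitrogen is also not enough on its own, since pentyl improves on directly attached phenyl with a 19-fold lower number from compound 3 to compound 4 (1.28 log units; beyond the scatter) as a large step, so the order on this nitrogen runs 1-phenylethyl, then pentyl, then phenyl. No measurement at hand explains either step.

The compounds shown do not separate the contribution of chain length from that of the ring, which a hexyl, cyclohexyl or 2-phenylethyl group on the same nitrogen would address. As far as these compounds go, the role of the stereocentre in 1-phenylethyl also stays open, as the opposite enantiomer is not among them.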